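The source may hold more compounds than are shown below. What is called first, only, known or untested is meant among the compounds shown, and "the series" means these compounds.

Measured compounds:
Compound 1, `CCN1CCN(c2cc(C)c3cc(NC(=O)c4ccc(Cl)cc4)ccc3n2)CC1`, gives 1530 nM in a functional assay on MCF7 cells (Homo sapiens) for antiproliferative activity, read by MTT assay, with a stated time of 72 h; on this read-out higher numbers stand for weaker inhibition and lower numbers for stronger inhibition.
Compound 2, `CCN1CCN(c2cc(C)c3cc(NC(=O)c4cccc(Br)c4)ccc3n2)CC1`, gives 11600 nM in this assay.

Compound 2 stands as the highest of the two numbers; its nearest neighbour is compound 1, and the step of a 7.6-fold higher number from compound 1 to compound 2 (0.88 log units; beyond the scatter) separates them. Compound 3, `CCN1CCN(c2cc(C)c3cc(NC(=O)c4ccccc4Cl)ccc3n2)CC1`, differs from compound 2 only in the ring attached to the carbonyl: 2-chlorophenyl in place of 3-bromophenyl on a carbonyl carbon. Among the compounds with values here, the one step that bears on this change, a 7.6-fold higher number from compound 1 to compound 2 (0.88 log units; beyond the scatter), shows that moving a halogen around this ring can shift the number beyond the scatter. Within the data shown here, the new ring has no measured counterpart, so the direction rests only on compound 2 being the highest of the two values. The step of a 2.3-fold lower number from compound 2 to compound 3 (0.37 log units; beyond the scatter) is therefore expected to be modest and towards a lower number, with real uncertainty either way. Compound 3 is estimated at 5000 nM, within 1500 nM to 20000 nM.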

Compound 3, half-maximal inhibitory concentration: > 50000 nM
Compound 3 gave a limit, no number (the forecaster's own chance of this, stated with the estimate: 5%); middle value at least 10-fold (1.00 log units) from the limit.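

Compound 3 gives a limit and not a number: the limit of > 50000 nM in this assay, at which 1 of the 3 values shown sits. Even so, the change to 2-chlorophenyl gives an at least 4.3-fold higher number from compound 2 to compound 3 (0.63 log units; beyond the scatter), so this ring can move the result further than the earlier pair showed. The step between compound 1 and compound 2 changed the halogen and its place together, whereas 2-chlorophenyl in place of 4-chlorophenyl keeps the halogen and changes only its place, and this alone gives an at least 32-fold higher number from compound 1 to compound 3 (1.51 log units; beyond the scatter).

The compounds shown leave open how much of the step to compound 2 belongs to the bromine and how much to its place, a question that a 3-chlorophenyl ring would help to answer. They also leave open how this assay would respond to an amine or a methoxy group on this ring in place of the halogen.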